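The source may report more compounds than this note shows. Statements on the series, on what has been measured and on what is new or still open speak of the compounds shown alone.

Among the measured compounds shown here, in a functional assay on HeLa cells (Homo sapiens) for antiproliferative activity, read by MTT assay, with a stated time of 72 h (on this read-out lower numbers stand for stronger inhibition and higher numbers for weaker inhibition), compound 3 `Cn1cc(Nc2nn(Cc3ccc(C(=O)NC4CCCCC4)cc3)c(=O)c3ccccc23)cn1` gives 3200 nM, the lower of the two actual numbers so far. Compound 1 `Cc1noc(C)c1-c1nn(Cc2ccc(C(=O)NC3CC(C)(C)N([O])C(C)(C)C3)cc2)c(=O)c2ccccc12` gives 83500 nM, a gap well beyond the usual scatter. Compound 2 `Cc1noc(C)c1-c1nn(Cc2ccc(C(=O)NC3CCN(C)CC3)cc2)c(=O)c2ccccc12` gives > 100000 nM, which is a limit of the assay and not a number.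

Compound 4 `Cc1noc(C)c1-c1nn(Cc2ccc(C(=O)NC3CCCCC3)cc2)c(=O)c2ccccc12` has not yet been measured. It keeps the amide side of compound 3 and differs in one place, on an aromatic carbon: 3,5-dimethyl-1,2-oxazol-4-yl in place of (1-methyl-1H-pyrazol-4-yl)amino on an aromatic carbon. Here, 3,5-dimethyl-1,2-oxazol-4-yl replaces (1-methyl-1H-pyrazol-4-yl)amino.

For the measured compounds named here, no measured step makes this swap directly. Going by the values given here, the only measured step, an at least 1.1-fold higher number from compound 1 to compound 2 (0.07 log units; that floor lies within the scatter), changes the amide side instead, so it offers little guidance. The better clue is that compound 1 carries the incoming group and gives 83500 nM, though its amide side differs from that of compound 4. A move to a higher number in this assay, beyond the scatter, therefore seems likely, and the expected step is a 6.3-fold higher number from compound 3 to compound 4 (0.80 log units; beyond the scatter). For compound 4, the estimated value is 20000 nM, with an expected range of 6000 nM to 80000 nM.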

Compound 4, half-maximal inhibitory concentration: > 100000 nM
Compound 4: a limit, no number (the forecaster's own chance of this, stated with the estimate: 15%); at least 5.0-fold (0.69 log units) between middle value and limit.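

Among the compounds shown here, this gives the first direct reading of the swap on this aromatic carbon: with the cyclohexyl amide held fixed, 3,5-dimethyl-1,2-oxazol-4-yl in place of (1-methyl-1H-pyrazol-4-yl)amino gives an at least 31-fold higher number from compound 3 to compound 4 (1.49 log units; beyond the scatter). That step is only a floor, because the value of compound 4 is a limit of the assay and not a number: the limit of > 100000 nM in this assay, at which 2 of the 4 values shown sit. With 3,5-dimethyl-1,2-oxazol-4-yl kept, changing the amide side gives an at least 1.1-fold higher number from compound 1 to compound 4 (0.07 log units; that floor lies within the scatter), and the step linking compound 2 and compound 4 cannot be read.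

The compounds shown do not separate the 1-methyl-1H-pyrazole ring from the amino link that joins it to the core, and a plain amine or a phenylamino group on this carbon would test that. They also leave open how the amide sides of compound 1 and compound 2 behave when paired with (1-methyl-1H-pyrazol-4-yl)amino.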